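Swapping the pendant aryl group on a fused dihydropyridine core

A few compounds are considered here, and "the series" means these few. Any claim that something is new, unique, unknown or untested is made for them only; others in the source may bear on it.

- compound 1 `COc1ccccc1C1C(C#N)=C(N)N(c2ccc(S(N)(=O)=O)cc2)C2=C1C(=O)CCC2`: 0%
- compound 2 `COc1ccc(C2C(C#N)=C(N)N(c3ccc(S(N)(=O)=O)cc3)C3=C2C(=O)CCC3)cc1`: 100%
- compound 3 `COc1cc(CC2C(C#N)=C(N)N(c3ccc(S(N)(=O)=O)cc3)C3=C2C(=O)CCC3)ccc1O`: 100%

Three compounds that share one core, and differ only in the group on a saturated ring carbon, have been tested in a functional assay on Ehrlich cells (Mus musculus) for antiproliferative activity, read by trypan blue exclusion, with a stated time of 2 h, tested at 100 ug/mL; on this read-out higher numbers stand for a stronger effect at the one concentration tested and lower numbers for a weaker effect. Compound 1 gives 0%, whereas compound 2 gives 100% and compound 3 gives 100%. Compound 3 therefore sits level with compound 2 at the top of the set, and both are far above compound 1: a number 100 percentage points higher from compound 1 to compound 3 (beyond the scatter), a number 100 percentage points higher from compound 1 to compound 2 (beyond the scatter).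

Compound 4 `N#CC1=C(N)N(c2ccc(S(N)(=O)=O)cc2)C2=C(C(=O)CCC2)C1c1cccc([N+](=O)[O-])c1` carries the change (3-nitrophenyl in place of 4-hydroxy-3-methoxybenzyl on a saturated ring carbon). The closest guide is no change at the digits printed from compound 2 to compound 3 (within the scatter), which shows that exchanging one aryl-type group for another left the read-out unchanged, while a number 100 percentage points higher from compound 1 to compound 2 (beyond the scatter) shows that such an exchange can also swing the result completely. Neither involves a nitro group, so the estimate is uncertain and leans on the two high values.

Compound 4 is expected to remain active in this assay, at about 80% (range 10% to 100%), meaning an expected step of a number 20 percentage points lower from compound 3 to compound 4 (beyond the scatter).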

Compound 4, a percentage reported as activity, at one concentration (the size of the read-out at that concentration, not a potency): 71%
Beside the measured number, compound 4's estimate is 9 percentage points above it; the range from low to high includes it.
By their numbers in this assay, from the lowest: compound 1; then compound 4; then compounds 2 and 3 (each within the scatter of the next).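

In this assay the 3-nitrophenyl group on this saturated ring carbon gives a result between the extremes seen so far, with a number 29 percentage points lower from compound 3 to compound 4 (beyond the scatter) and a number 29 percentage points lower from compound 2 to compound 4 (beyond the scatter) on one side, but a number 71 percentage points higher from compound 1 to compound 4 (beyond the scatter) on the other. Among the compounds shown here, this position can therefore give a partial read-out, not only all or nothing as the earlier compounds suggested. Compound 4 also shows that a substantial effect does not depend on a methoxy or hydroxy group on the pendant ring, since 3-nitrophenyl carries neither, and nothing available explains the size of these steps.

The compounds shown leave open how an amine or a carboxylic acid in place of the nitro group would behave. With one concentration tested, they show only a stronger or weaker effect at that concentration and leave open how these compounds would compare at any other.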